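Side chain swap from compound 3 to compound 4

A few compounds are considered here, and "the series" means these few. Any claim that something is new, unique, unknown or untested is made for them only; others in the source may bear on it.

Values in a functional assay on MCF7 cells (Homo sapiens) for cytotoxicity, read by MTT assay, with a stated time of 72 h; on this read-out higher numbers stand for weaker inhibition and lower numbers for stronger inhibition:
- compound 1 `CC1(C)O[C@@H](CO)[C@H](Cn2cc(Cn3c4c(c5ccccc53)C(=O)c3c[n+]([O-])c5ccccc5c3C4=O)nn2)O1`: 690 nM
- compound 2 `CCCN1CCN(CCCCn2c3c(c4ccccc42)C(=O)c2c[n+]([O-])c4ccccc4c2C3=O)CC1`: 1280 nM
- compound 3 `CN1CCN(CCCn2c3c(c4ccccc42)C(=O)c2c[n+]([O-])c4ccccc4c2C3=O)CC1`: 220 nM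

Compound 3 stands lowest of the three at 220 nM. Going to compound 4 `O=C1c2c[n+]([O-])c3ccccc3c2C(=O)c2c1c1ccccc1n2Cc1cn(C[C@@H](O)CO)nn1` is this change: 1-(2,3-dihydroxypropyl)-1H-1,2,3-triazol-4-yl in place of 2-(4-methylpiperazin-1-yl)ethyl on a saturated chain carbon bound to an aromatic nitrogen.

Among the compounds with values here, the only measured step is a 5.8-fold lower number from compound 2 to compound 3 (0.76 log units; beyond the scatter). It links two side chains that both hold a piperazine, so it says little about this swap. Within the data shown here, compound 1, the one measured compound carrying a triazole, gives 690 nM, which is the closest guide but is not linked to compound 4 by a measured step. A modest rise in this assay is therefore expected, estimated as a 3.4-fold higher number from compound 3 to compound 4 (0.53 log units; beyond the scatter). The expected value for compound 4 is 750 nM, with an estimated range of 250 nM to 2200 nM.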

Compound 4, half-maximal inhibitory concentration: 600 nM
Compound 4: middle estimate off by 1.3-fold (0.10 log units), on the high side, within the range that was stated.
By their numbers in this assay, from the lowest: compound 3; then compounds 4, 1 and 2 (each within the scatter of the next, the first and the last beyond it).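

In this assay, 1-(2,3-dihydroxypropyl)-1H-1,2,3-triazol-4-yl in place of 2-(4-methylpiperazin-1-yl)ethyl gives a 2.7-fold higher number from compound 3 to compound 4 (0.44 log units; beyond the scatter), so this position accepts a side chain with no piperazine at a modest loss. The same triazole side chain gives a 2.1-fold lower number from compound 2 to compound 4 (0.33 log units; beyond the scatter), so the two piperazine compounds do not both stand ahead of it. Among the triazoles, 1,2-dihydroxyethyl in place of 5-(hydroxymethyl)-2,2-dimethyl-1,3-dioxolan-4-yl gives a 1.2-fold lower number from compound 1 to compound 4 (0.06 log units; within the scatter), and the scatter covers that step.

Nothing available accounts for these steps.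

As far as these compounds go, whether an amine or a carboxylic acid in place of 1,2-dihydroxyethyl would keep these numbers stays open.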